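This account rests on a few compounds, and the source may have more. Where it says the series, first, only, none or still open, it means among the compounds named here.

Within the data shown here, in a functional assay on MCF7 cells (Homo sapiens) for inhibition, with a stated time of 48 h (on this read-out higher numbers stand for weaker inhibition and lower numbers for stronger inhibition), compound 1 (`COc1cc(Sc2c[nH]c3ccccc23)cc(OC)c1OC`) gives 34 nM, the lowest of the numbers measured so far. Compound 3 (`Cc1cc(C)cc(Sc2c[nH]c3ccc(Cl)cc23)c1`) is the nearest to it at 1200 nM, a gap well beyond the scatter. Compound 2 (`COc1ccccc1Sc1c[nH]c2ccc(Cl)cc12`) is reported as > 2500 nM, which is a limit of the assay and not a number.

The compound still awaiting measurement, compound 4 (`COc1cc(Sc2c[nH]c3ccc(F)cc23)cc(OC)c1OC`), departs from compound 1 in a single place: fluoro in place of hydrogen on an aromatic carbon. This puts fluoro in place of hydrogen on an aromatic carbon, in the six-membered aromatic ring of carbon only that is part of the fused system. Among the measured compounds shown here, compounds 2 and 3 each differ from compound 1 in more than one place, so no measured step isolates this change, and their higher values say little about it.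

Starting from compound 1 at 34 nM, a modest move towards weaker inhibition is expected in this assay, and it may not clear the scatter. The estimated change is a 1.8-fold higher number from compound 1 to compound 4 (0.25 log units; within the scatter). For compound 4 the expected value is 60 nM, with an estimated range of 15 nM to 300 nM.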

Compound 4, half-maximal inhibitory concentration: 160 nM
The estimate for compound 4 lay 2.7-fold (0.43 log units) below the measured number; the measured number falls inside the stated range.
By their numbers in this assay, from the lowest: compound 1; then compound 4; then compound 3. At a limit, above all of these: compound 2.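

In this assay, among these compounds, this is the first step that isolates a single change on the six-membered aromatic ring of carbon only in the fused system: fluoro in place of hydrogen brings a 4.7-fold higher number from compound 1 to compound 4 (0.67 log units; beyond the scatter), so this position is not indifferent to the change, even for a group of one heavy atom. The step is modest, and the change weakens inhibition without taking it out of measurable range, since compound 4 still gives a number, 160 nM, and not a limit of the assay. Nothing in the data shown gives a reason for this step.

As far as these compounds go, what a nitrile or an amine at this same place would do to the core of compound 1 remains open, and with a single replacement of hydrogen at this position, it cannot yet be said whether the loss belongs to fluoro in particular or to any group placed there. Also open, from the compounds shown here alone, is whether fluoro on another carbon of the same ring would give a step of similar size.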